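Removing the Hydroxy Group from Compound 1

The compounds below may be only part of what the source reports. "The series", "measured", "known", "first", "only" and "open" are said of these compounds alone.

Within the data shown here, compound 1 `Cc1nc(C)c(C(=O)Oc2ccc(/C=C/C(=O)O)cc2O)nc1C` stands at the top of the three numbers known so far. In a functional assay on a cell-free system (Platelet, plasma, Oryctolagus cuniculus) for inhibition, with a stated time of 5 min, at 37 degrees C (a lower number here means a stronger inhibitor, a higher number a weaker inhibitor), compound 1 gives 84600 nM. Compound 3 `COc1ccc(/C=C/C(=O)O)cc1OC(=O)c1nc(C)c(C)nc1C` gives 41800 nM, and compound 2 `Cc1nc(C)c(C(=O)Oc2cccc(/C=C/C(=O)O)c2)nc1C` gives 26400 nM; both lie beyond the scatter below compound 1, compound 2 furthest. Compound 4 `Cc1nc(C)c(C(=O)Oc2ccc(/C=C/C(=O)O)cc2)nc1C` has not yet been measured. It differs from compound 1 in one place: hydrogen in place of hydroxy on an aromatic carbon The hydroxy leaves an aromatic carbon that is ortho to a large group and meta to the 2-carboxyethenyl group, and a hydrogen takes its place. Among the measured compounds shown here, only one measured step alters a substituent on that ring: a 1.6-fold higher number from compound 2 to compound 3 (0.20 log units; within the scatter), a small movement for putting a group onto a bare carbon. Taking a group away at a different position is expected to move the number only modestly, and since the two other compounds sit lower, a somewhat lower number is expected, a 1.9-fold lower number from compound 1 to compound 4 (0.27 log units; within the scatter). Compound 4 is therefore estimated at 45000 nM, with a likely range from 18000 nM to 110000 nM.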

Compound 4, half-maximal inhibitory concentration: 37800 nM
Beside the measured number, compound 4's estimate is 1.2-fold (0.08 log units) above it, within the range that was stated.
By their numbers in this assay, from the lowest: compounds 2, 4 and 3 (each within the scatter of the next); then compound 1.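

Replacing the hydroxy with hydrogen gives a 2.2-fold lower number from compound 1 to compound 4 (0.35 log units; beyond the scatter) in this assay, so the inhibitor becomes modestly stronger when this group leaves. The carbon that is ortho to a large group and meta to a 2-carboxyethenyl group is therefore not indifferent to what it carries, at least for this pair. Among these compounds, the only earlier step with a substituent change (a 1.6-fold higher number from compound 2 to compound 3 (0.20 log units; within the scatter)) stayed within the scatter, whereas this one lies beyond it, and no measurement at hand explains the shift.

With only hydroxy and hydrogen compared at this carbon, the result gives a single step rather than a trend. Going by these compounds, how an amine, a chlorine atom or a longer chain on the same carbon would compare remains open.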